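Amidoxime in place of carbamate hydrazone on the shared core

The source may hold more compounds than are shown below. What is called first, only, known or untested is meant among the compounds shown, and "the series" means these compounds.

Compound 1 `COC(=N)c1c(Cl)n(C2O[C@H](CO)[C@@H](O)[C@H]2O)c2cc(Cl)c(Cl)cc12` gives 50000 nM in a functional assay on KB cells (Homo sapiens) for cytotoxicity, read by spectrophotometry and crystal violet staining; a lower number here means a stronger inhibitor, a higher number a weaker inhibitor.
Compound 2 `N/C(S)=N/N=C/c1c(Cl)n(C2O[C@H](CO)[C@@H](O)[C@H]2O)c2cc(Cl)c(Cl)cc12` gives 65000 nM in this assay.
Compound 3 `COC(=O)N/N=C/c1c(Cl)n(C2O[C@H](CO)[C@@H](O)[C@H]2O)c2cc(Cl)c(Cl)cc12` gives 20000 nM in this assay.

Compound 3 has the lowest number of the three; its nearest neighbour is compound 1, with a 2.5-fold lower number from compound 1 to compound 3 (0.40 log units; beyond the scatter), and compound 2 is further away, with a 3.3-fold lower number from compound 2 to compound 3 (0.51 log units; beyond the scatter). Compound 4 `N/C(=N\O)c1c(Cl)n(C2O[C@H](CO)[C@@H](O)[C@H]2O)c2cc(Cl)c(Cl)cc12` differs from compound 3 by a group of 4 heavy atoms (1 carbon, 2 nitrogen, 1 oxygen; no ring) in place of a group of 7 heavy atoms (3 carbon, 2 nitrogen, 2 oxygen; no ring), on an aromatic carbon. Among the compounds with values here, no measured pair shows this exact exchange. Within the data shown here, the steps that bear on it are those of compound 1, whose group at the same position is of similar size to the one that enters, namely a 2.5-fold lower number from compound 1 to compound 3 (0.40 log units; beyond the scatter) and a 1.3-fold higher number from compound 1 to compound 2 (0.11 log units; within the scatter). Since the smaller groups of compound 1 and compound 2 both sit well above compound 3, the expectation for compound 4 in this assay is a modest move upward, a 2.0-fold higher number from compound 3 to compound 4 (0.30 log units; within the scatter). The estimated value for compound 4 in this assay is therefore 40000 nM, within a range of 12000 nM to 130000 nM.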

Compound 4, half-maximal inhibitory concentration: > 100000 nM
Compound 4 gave a limit, no number; the forecaster's own chance of this, stated with the estimate: 15%; middle value at least 2.5-fold (0.39 log units) away from the limit.
By their numbers in this assay, from the lowest: compound 3; then compounds 1 and 2 (each within the scatter of the next). At a limit, above all of these: compound 4.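

In this assay compound 4 gives > 100000 nM as a limit of the assay and not a number. Within the data shown here, the exchange on this aromatic carbon opens a wider gap than any step among the earlier compounds, with an at least 5.0-fold higher number from compound 3 to compound 4 (0.69 log units; beyond the scatter) as its floor, so the group of compound 3 holds an edge that the group of compound 4 does not share. The floors of an at least 1.5-fold higher number from compound 2 to compound 4 (0.18 log units; that floor lies within the scatter) and of an at least 2.0-fold higher number from compound 1 to compound 4 (0.30 log units; that floor lies within the scatter) lie within the scatter and do not by themselves set compound 4 apart from those two compounds.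

Going by these compounds, how far the true value of compound 4 lies past its limit stays unknown. On these data alone, whether an amine or a carboxylic acid on this aromatic carbon, or a longer chain on the carbamate of compound 3, would keep or lower the number also stays open.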